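Fluoro for sulfo on the aryl of compound 1

The source may hold more compounds than are shown below. What is called first, only, known or untested is meant among the compounds shown, and "the series" means these compounds.

Measured compounds:
compound 1, `O=c1ccc(-c2ccccc2)nn1CCCC/N=C(\S)Nc1ccc(S(=O)(=O)O)cc1`: 25.1%
compound 2, `CCC/N=C(/NC#N)NCCCCCn1nc(-c2ccccc2)ccc1=O`: 27.5%
compound 3, `C/N=C(/NC#N)NCCCCn1nc(-c2ccc(C)cc2)ccc1=O`: 45.7%

In a functional assay on the whole organism with Rattus norvegicus as the target, at a dose of 100 mg/kg (a lower number here means less inhibition, a higher number more inhibition at the dose given (going by the name of the read-out)), compound 1 gives the lowest of the three numbers. Compound 2 lies within the scatter of it, so no order can be read between the two; compound 3 stands beyond the scatter above compound 1.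

Compound 4, `O=c1ccc(-c2ccccc2)nn1CCCC/N=C(\S)Nc1ccc(F)cc1`, is not yet measured. It differs from compound 1 in one place: fluoro in place of sulfo on an aromatic carbon. Among the compounds with values here, no step between measured compounds matches this change, so the expected size rests on the change alone. A modest upward shift in this assay is expected, estimated as a number 9.9 percentage points higher from compound 1 to compound 4 (within the scatter), a step of about the scatter itself. Compound 4 is therefore expected to give 35%, within 15% to 55%.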

Compound 4, a percentage reported as inhibition, in the whole organism at one dose (the size of the read-out at that dose, not a potency): 45.6%
Compound 4: middle estimate off by 10.6 percentage points, on the low side, and the stated range covers the measured number.
By their numbers in this assay, from the lowest: compounds 1 and 2 (each within the scatter of the next); then compounds 4 and 3 (each within the scatter of the next).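

In this assay, within the data shown here, replacing 4-sulfophenyl with 4-fluorophenyl gives a step of a number 20.5 percentage points higher from compound 1 to compound 4 (beyond the scatter), the first single-place comparison in this set. It shows that the read-out responds to the group on this aromatic carbon, para to a large group, when the rest of the structure stays fixed. No measurement shown accounts for the size of this step. Going by these compounds, whether an amine or a carboxylic acid at this place would read closer to sulfo or to fluoro stays open, as does the effect of a longer chain on compound 4 .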